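The compounds below may be only part of what the source reports. "The series", "measured", "known", "first", "only" and "open" are said of these compounds alone.

The measured compounds in an ADME assay on microsomes from liver (Homo sapiens) for metabolic stability, tested at 2.5 uM; a lower number here means slower removal, a higher number faster removal of the compound:

Compound 1 `Cc1ccc(S(=O)(=O)c2cnc3c(F)cccc3c2-c2ccc(Cl)cc2)cc1F`: 2.2 mL/min
Compound 2 `Cc1ccc(S(=O)(=O)c2cnc3c(F)cccc3c2-c2cccc(Cl)c2)cc1F`: 3.18 mL/min
Compound 3 `COc1ccc(-c2c(S(=O)(=O)c3ccc(C)c(F)c3)cnc3c(F)cccc23)cc1`: 3.27 mL/min

Compound 1 has the lowest number of the three in this assay. Its nearest neighbour is compound 2, reached by a 1.4-fold higher number from compound 1 to compound 2 (0.16 log units; within the scatter), and the furthest is compound 3, reached by a 1.5-fold higher number from compound 1 to compound 3 (0.17 log units; within the scatter). Both steps are within the scatter, so the three compounds cannot be ranked on these data.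

Compound 4 `O=S(=O)(c1cc(Cl)cc(Cl)c1)c1cnc2c(F)cccc2c1-c1ccc(Cl)cc1` is not yet measured. It differs from compound 1 in one place: 3,5-dichlorophenyl in place of 3-fluoro-4-methylphenyl on a sulfonyl sulfur. All three measured steps, including a 1.0-fold higher number from compound 2 to compound 3 (0.01 log units; within the scatter), change the aryl group attached to the core and leave the group on the sulfonyl sulfur untouched; none of them bears on the change from compound 1 to compound 4. The data therefore carry no information about this kind of change, and every step they do show lies within the scatter.

In that light compound 4 is expected to land near compound 1, with a step of a 1.3-fold higher number from compound 1 to compound 4 (0.10 log units; within the scatter) that is itself within the scatter. The estimate for compound 4 in this assay is 2.8 mL/min, with a range from 1.2 mL/min to 6.5 mL/min.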

Compound 4, intrinsic clearance in a liver preparation (reported as CLH), per the amount of preparation that the assay uses: 0.78 mL/min
Compound 4: middle estimate off by 3.6-fold (0.56 log units), on the high side; measured number below the stated range.
By their numbers in this assay, from the lowest: compound 4; then compounds 1, 2 and 3 (each within the scatter of the next).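

In this assay, the group on the sulfonyl sulfur proves able to move the number: 3,5-dichlorophenyl in place of 3-fluoro-4-methylphenyl gives a 2.8-fold lower number from compound 1 to compound 4 (0.45 log units; beyond the scatter), the only step among these compounds that is printed as beyond the scatter. The two groups have the same count of heavy atoms, and neither carries a hydrogen-bond donor, a hydrogen-bond acceptor or a net charge, so those counts do not separate them and the step cannot be tied to any of them. Nothing measured here accounts for the difference between the two groups.

This single exchange removes the fluorine and the methyl and brings in two chlorines all at once, so the compounds shown leave open which of these parts carries the step, and whether it would also appear with the other aryl groups on the shared core, such as the 4-methoxyphenyl of compound 3. They also leave open how the number would respond on this sulfonyl sulfur to a phenyl ring bearing an amine, a carboxylic acid or a nitrile.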